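This account rests on a few compounds, and the source may have more. Where it says the series, first, only, none or still open, it means among the compounds named here.

Compound 1 `O=C1CNc2nc(Nc3ccccc3)ncc2N1` is the parent of this small set. In a functional assay on MDA-MB-468 cells (Homo sapiens) for cytotoxicity, read by MTT assay, with a stated time of 48 h (a lower number here means a stronger inhibitor, a higher number a weaker inhibitor), compound 1 gives only a limit, > 100000 nM, and not a number. Compound 2 `O=C1CNc2nc(Nc3ccc(F)cc3)ncc2N1` likewise gives only a limit, > 100000 nM, in this assay. Compound 3 `O=C1CNc2nc(Nc3ccc(Cl)cc3)ncc2N1` gives 15000 nM in this assay. The picture is shaped by the limit of > 100000 nM in this assay, at which 2 of the 3 values shown sit. The readable steps are an at least 6.6-fold lower number from compound 1 to compound 3 (0.82 log units; beyond the scatter) and an at least 6.6-fold lower number from compound 2 to compound 3 (0.82 log units; beyond the scatter), while a step that the two limits leave unreadable from compound 1 to compound 2. All three concern a substituent on an aromatic carbon of the outer ring.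

Compound 4 `CN1CC(=O)Nc2cnc(Nc3ccccc3)nc21` differs from compound 1 in one place: methyl in place of hydrogen on a nitrogen on an aromatic ring in a ring. For the measured compounds named here, none of the measured steps touches this ring nitrogen, so they give no guide to the size or direction of the change, and compound 1 itself stands only at a limit. The step of a number no higher from compound 1 to compound 4 (the limit leaves the size open) is therefore expected to be nothing beyond the scatter. The estimate for compound 4 is 100000 nM, expected to fall between 30000 nM and 300000 nM, most likely again reported only as a limit.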

Compound 4, half-maximal inhibitory concentration: > 100000 nM
Compound 4: no number, only a limit; the forecaster's own chance of this, stated with the estimate: 75%; the middle value sits exactly at the limit.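

Compound 1 and compound 4 both give only a limit and no number, so no step between them can be read: the limit of > 100000 nM in this assay, at which 3 of the 4 values shown sit.

On these data alone, whether methyl in place of hydrogen on this ring nitrogen changes the true potency in this assay, in either direction, stays open.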